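Swapping an amide for a sulfonamide on a shared core

This account rests on a few compounds, and the source may have more. Where it says the series, first, only, none or still open, it means among the compounds named here.

Compound 1 `COc1ccc(S(=O)(=O)N2CCc3cccc(NC(=O)c4ccc(C#N)cc4)c32)cc1`: 105 nM
Compound 2 `COc1ccc(S(=O)(=O)N2CCc3cccc(NC(=O)c4ccncc4)c32)cc1`: 9.6 nM
Compound 3 `COc1ccc(S(=O)(=O)N2CCc3cccc(NC(=O)c4cccs4)c32)cc1`: 47 nM

In a functional assay on KB cells (Homo sapiens) for cytotoxicity (a higher number here means a weaker inhibitor, a lower number a stronger inhibitor), compound 3 gives the second highest of the three numbers: compound 1 sits a 4.9-fold higher number from compound 2 to compound 3 (0.69 log units; beyond the scatter) is the gap to compound 2, while a 2.2-fold lower number from compound 1 to compound 3 (0.35 log units; beyond the scatter). Compound 4 `COc1ccc(S(=O)(=O)N2CCc3cccc(NS(=O)(=O)c4ccc(F)cc4)c32)cc1` differs from compound 3 by (4-fluorophenyl)sulfonyl in place of (thiophen-2-yl)carbonyl on a nitrogen on an aromatic ring. Within the data shown here, the measured steps, an 11-fold lower number from compound 1 to compound 2 (1.04 log units; beyond the scatter) and a 2.2-fold lower number from compound 1 to compound 3 (0.35 log units; beyond the scatter), only exchange one aromatic ring for another on the carbonyl carbon; none replaces the carbonyl itself by a sulfonyl, so no step bears directly on this change. Because compound 3 gives 47 nM and the aryl swaps span an 11-fold lower number from compound 1 to compound 2 (1.04 log units; beyond the scatter), the expected value of compound 4 is 100 nM, between 20 nM and 500 nM, an estimated step of a 2.1-fold higher number from compound 3 to compound 4 (0.33 log units; beyond the scatter).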

Compound 4, half-maximal inhibitory concentration: 1200 nM
Compound 4: the middle estimate sits 12-fold (1.08 log units) below what was measured, outside the stated range (above it).
By their numbers in this assay, from the lowest: compound 2; then compound 3; then compound 1; then compound 4.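

In this assay, every carbonyl compound gives a higher number on moving to the (4-fluorophenyl)sulfonyl group, with a 26-fold higher number from compound 3 to compound 4 (1.41 log units; beyond the scatter) and a 130-fold higher number from compound 2 to compound 4 (2.10 log units; beyond the scatter) and an 11-fold higher number from compound 1 to compound 4 (1.06 log units; beyond the scatter). Unlike the ring swaps on the carbonyl, this change alters the link itself, and it leaves compound 4 the weakest of the four. Nothing measured here accounts for this loss.

On these data alone, the change replaces the link and the ring together, so the share of each stays open. A (4-fluorophenyl)carbonyl or a (thiophen-2-yl)sulfonyl group on the same nitrogen would separate them.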